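The source may report more compounds than this note shows. Statements on the series, on what has been measured and on what is new or still open speak of the compounds shown alone.

Measured so far in a functional assay on HeLa cells (Homo sapiens) for antiproliferative activity, read by MTT assay, with a stated time of 48 h; a lower number here means a stronger inhibitor, a higher number a weaker inhibitor:
- compound 1 `Clc1cc2nc(-c3cn(-c4ccccc4)nc3-c3ccccc3)[nH]c2cc1Cl` gives 13400 nM
- compound 2 `Fc1ccc(-c2nn(-c3ccccc3)cc2-c2nc3cc(Cl)ccc3[nH]2)cc1` gives 2770 nM

Compound 2 holds the lower of the two numbers, and its gap to compound 1 lies beyond the scatter. Compound 3 `Fc1ccc(-c2nn(-c3ccccc3)cc2-c2nc3cc(Cl)c(Cl)cc3[nH]2)cc1` derives from compound 2 by chloro in place of hydrogen on an aromatic carbon, ortho to a chloro group. Within the data shown here, no measured pair isolates this change. Compound 1 also carries two chloro groups and gives 13400 nM, which tilts the expectation towards a higher number. The expected move in this assay is small and probably not beyond the scatter, an estimated 1.6-fold higher number from compound 2 to compound 3 (0.21 log units; within the scatter). For compound 3 the estimated value is 4500 nM, with an expected range from 1400 nM to 14000 nM.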

Compound 3, half-maximal inhibitory concentration: 11600 nM
Beside the measured number, compound 3's estimate is 2.6-fold (0.41 log units) below it, within the range that was stated.
By their numbers in this assay, from the lowest: compound 2; then compounds 3 and 1 (each within the scatter of the next).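

In this assay, chloro in place of hydrogen on an aromatic carbon, ortho to a chloro group, weakens the series at this position (a 4.2-fold higher number from compound 2 to compound 3 (0.62 log units; beyond the scatter)). With both chloro groups present, adding the fluoro group gives no separable shift (a 1.2-fold lower number from compound 1 to compound 3 (0.06 log units; within the scatter)). No measurement available here accounts for the loss from the added chloro group.

As far as these compounds go, whether a methoxy group or an amine at this aromatic carbon would behave like chloro stays open. Also open, from the compounds shown here alone, is whether the fluoro step would stay within the scatter on a core carrying a single chloro group.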